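A few compounds are considered here, and "the series" means these few. Any claim that something is new, unique, unknown or untested is made for them only; others in the source may bear on it.

Compound 3 `CN(C)c1ncnc2c1c(-c1cc3ccccc3o1)cn2[C@@H]1O[C@H](CO)[C@@H](O)[C@H]1O` was examined in a functional assay on HeLa S3 cells (Homo sapiens) for antiproliferative activity, read by XTT assay, with a stated time of 72 h; on this read-out lower numbers stand for stronger inhibition and higher numbers for weaker inhibition. In this assay compound 3 gives > 20000 nM, which is a limit of the assay and not a number. Two related compounds stand the same way. In this assay compound 1 `CNc1ncnc2c1c(-c1cccs1)cn2[C@@H]1O[C@H](CO)[C@@H](O)[C@H]1O` gives > 20000 nM, a limit of the assay. In this assay compound 2 `CNc1ncnc2c1c(-c1ccoc1)cn2[C@@H]1O[C@H](CO)[C@@H](O)[C@H]1O` gives > 20000 nM, again a limit of the assay. Going by the values given here, the only step between measured compounds, a step that the two limits leave unreadable from compound 1 to compound 2, is left unreadable by the two limits, and the limit of > 20000 nM in this assay, at which 3 of the 3 values shown sit, shows all three values sitting at that limit.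

Compound 4 `CNc1ncnc2c1c(-c1cc3ccccc3o1)cn2[C@@H]1O[C@H](CO)[C@@H](O)[C@H]1O` has not yet been measured. It differs from compound 3 in one place: hydrogen in place of methyl on a nitrogen on an aromatic ring. The same difference, cut one bond further out, reads dimethylamino to methylamino. No measured step touches this nitrogen, so nothing shown speaks to the size or direction of the change; compounds 1 and 2 carry the methylamino group of compound 4 and sit at the limit, and compound 3 with the dimethylamino group sits at the same limit. The expected step is a step that the limit leaves unreadable from compound 3 to compound 4, which amounts to none that can be read. Compound 4 is therefore expected to give about 30000 nM in this assay, with a range from 5000 nM to 200000 nM, and most likely only a limit will be reported.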

Compound 4, half-maximal inhibitory concentration: > 20000 nM
Compound 4 ended at the assay's limit; the forecaster's own chance of this, stated with the estimate: 80%; the middle value lies beyond the limit too.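

Compound 4 stands at a limit of this assay and not at a number, as do compound 1, compound 2 and compound 3, so none of the steps from those three compounds to compound 4 can be read. The compounds shown leave open how strongly any of them acts in this assay and whether changing either the amino group or the group on the aromatic carbon moves that read-out at all.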